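Dimethylamino in Place of the Diethoxy Chain End

This account rests on a few compounds, and the source may have more. Where it says the series, first, only, none or still open, it means among the compounds named here.

Compound 1 `CCOC(CCn1c(Cc2nn(C)c(=O)c3ccccc23)nnc1SCCCCCCCC(=O)Nc1ccc(Cl)cc1Cl)OCC` — 12100 nM
Compound 2 `Cn1nc(Cc2nnc(SCC(=O)Nc3ccc(Cl)cc3Cl)n2CCCO)c2ccccc2c1=O` — limit, > 30000 nM
Compound 3 `Cn1nc(Cc2nnc(SCC(=O)Nc3ccc(Cl)cc3Cl)n2CCC(=O)O)c2ccccc2c1=O` — limit, > 30000 nM

Among the compounds with values here, in an assay on 32D cells for inhibition of interleukin-15 (Mus musculus), read by resazurin assay, with stated times of 30 min and 2.5 days, in the presence of a further agent that is not named here (a lower number here means a stronger inhibitor, a higher number a weaker inhibitor), compound 1 gives 12100 nM, the only number among the three values shown. Compound 2 reaches only the limit of the assay, > 30000 nM. Compound 3 likewise sits at the limit, > 30000 nM. The step that the two limits leave unreadable from compound 2 to compound 3 cannot be read because the limit of > 30000 nM in this assay, at which 2 of the 3 values shown sit, covers both of its ends.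

Compound 4 `CN(C)CCCn1c(Cc2nn(C)c(=O)c3ccccc23)nnc1SCCCCCCCC(=O)Nc1ccc(Cl)cc1Cl` differs from compound 1 by (dimethylamino)methyl in place of diethoxymethyl on a saturated chain carbon, two bonds along the chain from an aromatic nitrogen. The only measured step at this place on the chain is the unreadable one, so nothing shown argues for a move beyond the scatter. Compound 4 is therefore expected near 12000 nM, within 4000 nM to 30000 nM. The step of a 1.0-fold lower number from compound 1 to compound 4 (0.00 log units; within the scatter) is estimated to stay within the scatter.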

Compound 4, half-maximal inhibitory concentration: 3700 nM
Estimate against measurement, compound 4: 3.2-fold (0.51 log units) above, outside the stated range (below it).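

In this assay, this chain end now gives a readable step, a 3.3-fold lower number from compound 1 to compound 4 (0.51 log units; beyond the scatter), so 3-(dimethylamino)propyl in place of 3,3-diethoxypropyl moves the number modestly beyond the scatter. The earlier step at this place cannot be read, because both of its ends sit at a limit: the limit of > 30000 nM in this assay, at which 2 of the 4 values shown sit.

On these data alone, it remains open whether this step depends on the dimethylamino group itself. A pyrrolidine, a morpholine, a carboxylic acid or a longer chain at this place, with the rest of compound 4 unchanged, would show how far the number follows the group at the chain end.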